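This account rests on a few compounds, and the source may have more. Where it says the series, first, only, none or still open, it means among the compounds named here.

Measured compounds:
- compound 1 `CCc1ccc2nc(C(=O)Nc3c(F)cc(-c4cccc(F)c4)cc3F)c(C)c(O)c2c1`: 1.57%
- compound 2 `COc1ccc2nc(C(=O)Nc3ccc(-c4ccccc4)cc3)c(C)c(O)c2c1`: 3.05%
- compound 3 `CCc1ccc2nc(C(=O)Nc3c(F)cc(-c4cccc(F)c4)cc3F)c(C)c(C(=O)O)c2c1`: 2.45%

All three were read in a functional assay on A-375 cells (Homo sapiens) for antiproliferative activity, read by MTT assay, with a stated time of 24 h, tested at 0.14 ug/mL (on this read-out higher numbers stand for a stronger effect at the one concentration tested and lower numbers for a weaker effect), and all three numbers sit low. Compound 3 gives the second highest of the three numbers; its nearest neighbour is compound 2 and its furthest is compound 1, and both gaps lie within the scatter. The one single-point step so far, a number 0.9 percentage points higher from compound 1 to compound 3 (within the scatter), is also within the scatter, so no change shown in this set has moved the read-out beyond noise.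

Compound 4 `COc1ccc2nc(C(=O)Nc3c(F)cc(-c4cccc(F)c4)cc3F)c(C)c(C(=O)O)c2c1` differs from compound 3 by one change: methoxy in place of ethyl on an aromatic carbon. Within the data shown here, no measured step covers this exchange. Compound 2 also carries methoxy, but it differs from compound 3 in more than one place, so its value only shows that a methoxy-bearing analogue stays in the same low band. With nothing pointing either way, the step of a number 0.1 percentage points higher from compound 3 to compound 4 (within the scatter) is expected to lie within the scatter, with no direction. Compound 4 is therefore estimated at 2.5%, within -3% to 8%.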

Compound 4, a percentage reported as inhibition, at one concentration (the size of the read-out at that concentration, not a potency): 2.06%
Beside the measured number, compound 4's estimate is 0.4 percentage points above it; low and high end bracket the measured number.
By their numbers in this assay, from the lowest: compounds 1, 4, 3 and 2 (each within the scatter of the next).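

In this assay, among these compounds, a number 0.4 percentage points lower from compound 3 to compound 4 (within the scatter) is the first step read at this position, on an aromatic carbon of a six-membered aromatic ring of carbon only, and it lies within the scatter. Ethyl and methoxy count the same heavy atoms, but methoxy brings a hydrogen-bond acceptor that ethyl lacks, and with carboxy on the core this exchange does not move the read-out beyond noise. The data shown offer no explanation for this result.

As far as these compounds go, whether an amine or a longer chain such as butyl at this position would stay in the same low band remains open. Also open, from the compounds shown here alone, is whether the exchange of ethyl for methoxy would read the same with hydroxy in place of carboxy on the shared core.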